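Rearranging Fluorines on the Benzyl Arm of an Indole Acid

This account rests on a few compounds, and the source may have more. Where it says the series, first, only, none or still open, it means among the compounds named here.

Compound 1 `COc1cccc2c1c(C(=O)/C=C(\O)C(=O)O)cn2Cc1c(F)cccc1F` is measured in an ADME assay on MT4 cells (Homo sapiens) for cytotoxicity, read by MTT assay (a higher number here means that more compound is tolerated, a lower number that less compound is tolerated), and gives 44300 nM. Its ethyl ester relatives are compound 2 `CCOC(=O)/C(O)=C/C(=O)c1cn(Cc2ccc(F)c(F)c2F)c2cccc(OC)c12` and compound 3 `CCOC(=O)/C(O)=C/C(=O)c1cn(Cc2cc(F)c(F)c(F)c2)c2cccc(OC)c12`. In this assay compound 2 gives 42700 nM, and compound 3 gives 33400 nM. Compound 1 does not stand apart from either of them: all three numbers lie within the usual scatter of one another, so no order among them can be claimed.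

Compound 4 `COc1cccc2c1c(C(=O)/C=C(\O)C(=O)O)cn2Cc1cc(F)cc(F)c1` differs from compound 1 only in the pattern of the two fluorines on the benzyl arm: 3,5-difluorophenyl in place of 2,6-difluorophenyl on a saturated chain carbon bound to an aromatic nitrogen.

Among the compounds with values here, one measured step bears on this kind of change. Moving fluorines around the same ring gave a 1.3-fold lower number from compound 2 to compound 3 (0.11 log units; within the scatter), a change that did not rise above the scatter. On this basis compound 4 is expected to show no movement beyond the scatter in this assay, so the estimated step is a 1.0-fold lower number from compound 1 to compound 4 (0.00 log units; within the scatter). Compound 4 is therefore estimated at 44000 nM, with a range from 25000 nM to 80000 nM.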

Compound 4, half-maximal cytotoxic concentration: 29500 nM
Beside the measured number, compound 4's estimate is 1.5-fold (0.17 log units) above it, and the stated range covers the measured number.
By their numbers in this assay, from the lowest: compounds 4, 3, 2 and 1 (each within the scatter of the next).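

Exchanging 2,6-difluorophenyl for 3,5-difluorophenyl on a saturated chain carbon bound to an aromatic nitrogen gives a 1.5-fold lower number from compound 1 to compound 4 (0.18 log units; within the scatter) in this assay, so this pair of fluorine patterns cannot be told apart in this measurement. The earlier step concerned trifluorophenyl groups on ethyl esters, whereas this one extends the same reading to difluorophenyl groups on the carboxylic acid, and here too rearranging the fluorines stays within the scatter. Nothing available on these compounds gives a cause for any of these numbers.

The compounds shown leave open whether a chlorine atom or a methoxy group on the benzyl ring, or a longer chain joining that ring to the aromatic nitrogen, would move the number beyond the scatter. They also leave open how a carboxylic acid and its ethyl ester compare when both carry the same fluorine pattern.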